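The compounds below may be only part of what the source reports. "The series", "measured", "known", "first", "only" and "open" are said of these compounds alone.

Compound 1 `O=C(NC/C=C\Cn1ccc(=O)[nH]c1=O)c1ccccc1`: in a functional assay on SK-BR-3 cells (Homo sapiens) for cytotoxicity, read by MTT assay, with a stated time of 72 h (a lower number here means a stronger inhibitor, a higher number a weaker inhibitor), compound 1 gives > 100000 nM, a limit of the assay.
Compound 2 `O=C(NC/C=C\Cn1cc(F)c(=O)[nH]c1=O)c1ccccc1`: in this assay compound 2 gives > 100000 nM, also a limit.
Compound 3 `Cc1cn(C/C=C\CNC(=O)c2ccccc2)c(=O)[nH]c1=O`: in this assay compound 3 gives > 100000 nM, again a limit.

Compound 3 therefore stands nowhere in particular: its value is only a limit, and the same holds for the other two, all three sitting at the limit of > 100000 nM in this assay, at which 3 of the 3 values shown sit. The steps a step that the two limits leave unreadable from compound 1 to compound 2, a step that the two limits leave unreadable from compound 1 to compound 3 and a step that the two limits leave unreadable from compound 2 to compound 3 are accordingly unreadable in size and direction. Compound 4 `O=C(NC/C=C\Cn1cc(C(F)(F)F)c(=O)[nH]c1=O)c1ccccc1` differs from compound 3 by trifluoromethyl in place of methyl on an aromatic carbon. Among the measured compounds shown here, no measured step shows this change, and none of the measured steps is readable, so no step beyond the scatter is expected in this assay; most likely compound 4 will again give only a limit. The estimate for compound 4 in this assay is 150000 nM, between 50000 nM and 500000 nM, an expected step that the limit leaves unreadable from compound 3 to compound 4.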

Compound 4, half-maximal inhibitory concentration: > 100000 nM
Compound 4 was reported as a limit; the forecaster's own chance of this, stated with the estimate: 85%; the middle value does not contradict the limit.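

Among the compounds shown here, compound 4 gives only a limit, as do compound 1, compound 2 and compound 3, so no step among them can be read: the limit of > 100000 nM in this assay, at which 4 of the 4 values shown sit. The compounds shown leave open whether any group at this place on the shared core would give a measurable value in this assay.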